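The source may hold more compounds than are shown below. What is called first, only, known or untested is meant among the compounds shown, and "the series" means these compounds.

Compound 1 `COc1cc2c(Nc3ccc(OCc4cccc(F)c4)c(Cl)c3)ncnc2cc1OCCCCCn1ccnc1[N+](=O)[O-]`, compound 2 `COc1cc2c(Nc3ccc(OCc4cccc(F)c4)c(Cl)c3)ncnc2cc1OCCOCCn1ccnc1[N+](=O)[O-]`, compound 3 `COc1cc2c(Nc3cccc(Br)c3)ncnc2cc1OCCCCCn1ccnc1[N+](=O)[O-]` and compound 4 `COc1cc2c(Nc3cccc(Br)c3)ncnc2cc1OCCOCCn1ccnc1[N+](=O)[O-]` share a 2-nitro-1H-imidazol-1-yl group fixed to the core through a chain that runs from an oxygen on an aromatic ring. Three of them have been measured in a functional assay on HT-29 cells (Homo sapiens) for inhibition, read by sulforhodamine B assay, with a stated time of 72 h; a lower number here means a stronger inhibitor, a higher number a weaker inhibitor. In this assay compound 1 gives 14100 nM, compound 2 gives 7640 nM and compound 3 gives 5050 nM.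

Compound 2 differs from compound 1 by 2-(2-nitro-1H-imidazol-1-yl)ethoxy in place of 3-(2-nitro-1H-imidazol-1-yl)propyl on a saturated chain carbon, two bonds along the chain from an oxygen on an aromatic ring. That change made a 1.8-fold lower number from compound 1 to compound 2 (0.27 log units; within the scatter). Compound 4 differs from compound 3 by the same change, (2-(2-nitro-1H-imidazol-1-yl)ethoxy in place of 3-(2-nitro-1H-imidazol-1-yl)propyl on a saturated chain carbon, two bonds along the chain from an oxygen on an aromatic ring), and the place is described in the same words for both pairs, so it is the same change on a different core. Compound 1 and compound 3 carry different cores, and the difference between the two cores is not broken down here; what can be said is that compound 1 gives 14100 nM while compound 3 gives 5050 nM.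

Among the measured compounds shown here, since the one earlier instance of this change gave a small step, a comparable step is expected from compound 3 to compound 4, a 1.4-fold lower number from compound 3 to compound 4 (0.16 log units; within the scatter), resting on the measured step of a 1.8-fold lower number from compound 1 to compound 2 (0.27 log units; within the scatter). On that basis compound 4 is estimated to give 3500 nM in this assay, most likely between 1800 nM and 8000 nM.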

Compound 4, half-maximal inhibitory concentration: 10800 nM
For compound 4 the middle estimate is 3.1-fold (0.49 log units) below the measured one; the measured number lies above the stated range.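

On the core of compound 3, the change from 3-(2-nitro-1H-imidazol-1-yl)propyl to 2-(2-nitro-1H-imidazol-1-yl)ethoxy gave a 2.1-fold higher number from compound 3 to compound 4 (0.33 log units; beyond the scatter) in this assay, a modest step that counts as a real difference. Set beside the earlier pair, the same change does not give the same result on the two cores: the same change on two cores in this assay, a 1.8-fold lower number (0.27 log units; within the scatter) from compound 1 to compound 2 and a 2.1-fold higher number (0.33 log units; beyond the scatter) from compound 3 to compound 4, 3.9-fold (0.60 log units) apart, beyond the scatter of two such steps This shows that, for these two pairs, the result of the change on one core could not simply be carried over to the other, but it does not show which part of the two cores is responsible, and two pairs, one of them a step within the scatter, make no general rule for the series.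

The compounds shown leave open how the change would behave on a third core, and so whether either pair is the more typical one. They also leave open what a longer chain, or an amine within the chain in place of the added oxygen, would do on each core, and whether the nitro group on the imidazole matters to these numbers at all.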